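Methyl on the ring amide nitrogen: an unmeasured step

The source may report more compounds than this note shows. Statements on the series, on what has been measured and on what is new or still open speak of the compounds shown alone.

Measured compounds and their values in a functional assay on the whole organism (strain Wister albino) for inhibition, with Rattus norvegicus as the target, read by paw edema, with stated times of 1 h and 2 h, at a dose of 50 mg/kg by the intraperitoneal route; on this read-out higher numbers stand for more inhibition at the one dose given (going by the name of the read-out) and lower numbers for less inhibition:
compound 1, `CN1C[C@@H](c2ccc(F)cc2)[C@@]2(Cc3ccccc3C2=O)[C@@]12C(=O)Nc1ccccc12`: 21.2%
compound 2, `CN1C[C@@H](c2cccs2)[C@@]2(Cc3ccccc3C2=O)[C@@]12C(=O)Nc1ccccc12`: 39.1%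
compound 3, `CN1C[C@@H](c2ccco2)[C@@]2(Cc3ccccc3C2=O)[C@@]12C(=O)Nc1ccccc12`: 53.6%

Compound 2 holds the middle place of the three. Its nearest neighbour is compound 3, a step of a number 14.5 percentage points higher from compound 2 to compound 3 (beyond the scatter); its furthest is compound 1, reached by a number 17.9 percentage points higher from compound 1 to compound 2 (beyond the scatter). Compound 4, `CN1C(=O)[C@@]2(c3ccccc31)N(C)C[C@@H](c1cccs1)[C@@]21Cc2ccccc2C1=O`, differs from compound 2 only in one place: methyl in place of hydrogen on an amide-type nitrogen in a ring. None of the three measured steps bears on this change; all of them exchange the group on the saturated ring carbon, and the ring amide nitrogen is untouched in every measured compound. The study therefore offers no guide to direction or size, and the expectation is a step within the scatter: a number 0.1 percentage points lower from compound 2 to compound 4 (within the scatter). Compound 4 is estimated at 39%, with a range from 22% to 56%.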

Compound 4, a percentage reported as inhibition, in the whole organism at one dose (the size of the read-out at that dose, not a potency): 10.8%
Compound 4: middle estimate off by 28.2 percentage points, on the high side; measured number below the stated range.
By their numbers in this assay, from the lowest: compound 4; then compound 1; then compound 2; then compound 3.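

The ring amide nitrogen, unchanged across compound 1, compound 2 and compound 3, proves not to be a silent position in this assay: methyl in place of hydrogen there gives a number 28.3 percentage points lower from compound 2 to compound 4 (beyond the scatter) and takes compound 4 below all three. A change of one heavy atom at this nitrogen thus moves the number beyond the scatter, so the group on the saturated ring carbon is not the only place that counts. The data shown offer no explanation for this drop.

On these data alone, whether ethyl or an acetyl group on this nitrogen would act like methyl remains open. So does whether methyl would lower the number with furan-2-yl or 4-fluorophenyl on the saturated ring carbon.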